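This account rests on a few compounds, and the source may have more. Where it says the series, first, only, none or still open, it means among the compounds named here.

Measured so far in a functional assay on HL-60 cells (Homo sapiens) for cytotoxicity, read by luminescence and CellTiter-Glo, with a stated time of 3 days; a lower number here means a stronger inhibitor, a higher number a weaker inhibitor:
- compound 1 `O=C(Nc1cc(C(F)(F)F)cc(C(F)(F)F)c1)c1cc(Br)c(-c2ccccc2)cc1O`: 430 nM
- compound 2 `N#Cc1ccc(NC(=O)c2ccc3cccnc3c2O)cc1`: 370 nM

Going by the values given here, only two numbers are available. Compound 1, at 430 nM, cannot be told apart from compound 2, at 370 nM, since the two values lie within the usual scatter of repeated measurements. The two structures also differ in more than one place, so this pair says nothing about the effect of any single group.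

The next compound, compound 3 `O=C(Nc1cc(C(F)(F)F)cc(C(F)(F)F)c1)c1cc(Br)ccc1O`, keeps most of compound 1 but has hydrogen in place of phenyl on an aromatic carbon, ortho to a bromo group and meta to a hydroxy group (hydrogen in place of phenyl on an aromatic carbon). Among the compounds with values here, no measured pair shows what removing the phenyl does, so the expectation rests on little, and the range must stay wide. In this assay the expectation is no step beyond the scatter, with neither direction favoured with any confidence. The estimated step is a 1.2-fold higher number from compound 1 to compound 3 (0.07 log units; within the scatter). For compound 3 the estimated value is 500 nM, with an expected range from 150 nM to 1800 nM.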

Compound 3, half-maximal inhibitory concentration: 290 nM
For compound 3 the middle estimate is 1.7-fold (0.24 log units) above the measured one; the measured number falls inside the stated range.
By their numbers in this assay, from the lowest: compounds 3, 2 and 1 (each within the scatter of the next).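

In this assay, replacing the phenyl group with hydrogen on this aromatic carbon gives a 1.5-fold lower number from compound 1 to compound 3 (0.17 log units; within the scatter). Going by these compounds alone, this is the first single-place comparison, and it shows that losing the phenyl, with its 6 heavy atoms and its whole aromatic ring, from the position ortho to a bromo group and meta to a hydroxy group leaves no difference that can be told apart from repeat-measurement noise. Within the data shown here, for this pair, then, the large phenyl group is not required to keep the number in the same range, although nothing measured so far explains why the two compounds read alike.

Phenyl and hydrogen are the only two groups compared at this carbon, so it remains open whether a smaller or differently built group, such as a methoxy group, an amine or a carboxylic acid, would move the number beyond the scatter. From the compounds shown here alone, it also remains open whether the bromo group, the hydroxy group or the two trifluoromethyl groups can be changed as freely as the phenyl, since each has yet to be compared in a single-place step.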